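The compounds below may be only part of what the source reports. "The series", "measured", "known", "first", "only" and "open" are said of these compounds alone.

Measured in a functional assay on KB-V1 cells (Homo sapiens) for cytotoxicity, read by MTT assay, with a stated time of 72 h; a lower number here means a stronger inhibitor, a higher number a weaker inhibitor:
Compound 1 `O=C1Nc2ccccc2/C1=N/NC(=S)Nc1ccccc1`: 1470 nM
Compound 2 `O=C1Nc2ccccc2/C1=N/NC(=S)Nc1cccnc1`: > 50000 nM (a limit of the assay, not a number)
Compound 3 `O=C1Nc2ccccc2/C1=N/NC(=S)NC1CCCCC1`: 4380 nM

Compound 1 holds the lowest number shown in this assay. Compound 4 `COc1ccccc1NC(=S)N/N=C1\C(=O)Nc2ccccc21` keeps all of compound 1 and makes one change, methoxy in place of hydrogen on an aromatic carbon, ortho to a large group.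

Among the measured compounds shown here, no measured step makes this kind of change. Each one replaces the whole phenyl on the amide-type nitrogen, so they bear on it only indirectly. Going to cyclohexyl gave a modest step, a 3.0-fold higher number from compound 1 to compound 3 (0.47 log units; beyond the scatter). Going to pyridin-3-yl gave a large one that ends at the limit, an at least 34-fold higher number from compound 1 to compound 2 (1.53 log units; beyond the scatter). Compound 4 retains the carbon-only aromatic ring, so a small rise is expected, possibly none beyond the scatter, and nothing on the scale of an at least 34-fold higher number from compound 1 to compound 2 (1.53 log units; beyond the scatter). The estimated change is a 1.5-fold higher number from compound 1 to compound 4 (0.18 log units; within the scatter). For compound 4 the expected value is 2200 nM, with an estimated range from 700 nM to 7000 nM.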

Compound 4, half-maximal inhibitory concentration: 2690 nM
Compound 4: middle estimate off by 1.2-fold (0.09 log units), on the low side, within the range that was stated.
By their numbers in this assay, from the lowest: compounds 1, 4 and 3 (each within the scatter of the next, the first and the last beyond it). At a limit, above all of these: compound 2.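

In this assay, methoxy in place of hydrogen on an aromatic carbon, ortho to a large group, gives a 1.8-fold higher number from compound 1 to compound 4 (0.26 log units; within the scatter). This is the only step shown that keeps the phenyl on the amide-type nitrogen and changes it rather than replacing it whole, and it shows that this place can carry a methoxy without a change beyond the scatter. Nothing shown here gives a cause for this step.

Going by these compounds, it remains open whether this holds for other groups at the same place, such as an amine, a carboxylic acid or a longer chain like butoxy. On these data alone, it also remains open whether a methoxy elsewhere on the same ring would give a similar number, since this single result speaks for one group at one place.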